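Amide side chain swap on the benzoyl-bearing core

The source may report more compounds than this note shows. Statements on the series, on what has been measured and on what is new or still open speak of the compounds shown alone.

Three compounds have numbers in an ADME assay for permeability, using PAMPA, at pH 7.4; a higher number here means that the compound crosses the layer faster, a lower number that the compound crosses the layer more slowly. Compound 1 `c1cc2ccc(CN3CCCCC3)ccc-2c1` gives 3.4 10^-6 cm/s. Compound 2 `O=C(NCCO)c1ccc2ccc(C(=O)c3ccccc3)c-2cc1` gives 1.8 10^-6 cm/s, the lowest of the three, though its gap to compound 1 is within the scatter; compound 3 `O=C(Nc1cc2cccccc-2c1)c1cccnc1` gives 4.8 10^-6 cm/s, which lies beyond the scatter above compound 2. Going by the values given here, no two measured compounds differ in only one place, so no measured step is available to guide the next change.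

Compound 4 `O=C(NCc1cccnc1)c1ccc2ccc(C(=O)c3ccccc3)c-2cc1` has not yet been measured in this assay. It differs from compound 2 by pyridin-3-yl in place of hydroxymethyl on a saturated chain carbon bound to an amide-type nitrogen. The change takes away the hydrogen-bond donor that compound 2 carries and brings in an aromatic ring, while the amide and the benzoyl-bearing core stay as they are.

Without a matching measured step, the expected size rests only on the spread of the three numbers and on what is counted in the change. Compound 4 is expected to sit above compound 2, with an estimated step of a 2.8-fold higher number from compound 2 to compound 4 (0.44 log units; beyond the scatter) somewhat beyond the scatter. The estimate for compound 4 is 5 10^-6 cm/s, with a range from 2 10^-6 cm/s to 12 10^-6 cm/s.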

Compound 4, apparent permeability: 2.4 10^-6 cm/s
The estimate for compound 4 lay 2.1-fold (0.32 log units) above the measured number; low and high end bracket the measured number.
By their numbers in this assay, from the lowest: compounds 2, 4, 1 and 3 (each within the scatter of the next, the first and the last beyond it).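

In this assay, this position now has its first measured step, a 1.3-fold higher number from compound 2 to compound 4 (0.12 log units; within the scatter), and the two compounds cannot be told apart in this read-out. Going by these compounds alone, on the saturated chain carbon bound to an amide-type nitrogen, pyridin-3-yl in place of hydroxymethyl takes away the hydrogen-bond donor and brings in a six-membered aromatic ring, yet this larger exchange on the shared core leaves the number within the scatter, a finding that the earlier compounds, none of which differed in only one place, could not give. Nothing measured on these compounds accounts for this outcome.

The step changes the donor and the ring together, so the compounds shown do not separate the two, and a plain phenyl or a methoxymethyl at the same place would be needed to read each part alone. As far as these compounds go, it also remains open whether any group at this place moves the number beyond the scatter, for example a primary amine, a carboxylic acid or a longer chain bearing the same pyridin-3-yl.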